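Methyl for methoxy on the aryl ketone of compound 1

The source may report more compounds than this note shows. Statements on the series, on what has been measured and on what is new or still open speak of the compounds shown alone.

Compound 1 `COC(=O)c1c(Nc2ccccc2)sc(C(=O)c2ccc(OC)cc2)c1C` stands highest of the three measured compounds in a functional assay, with a stated time of 150 min, tested at 35 ug/mL (on this read-out lower numbers stand for a weaker effect and higher numbers for a stronger effect at the one concentration tested), with 63%. Compound 2 `COC(=O)c1c(Nc2ccc(OC)cc2)sc(C(=O)c2ccc(OC)cc2)c1C` gives 25.1% and compound 3 `COC(=O)c1c(Nc2ccc(F)cc2)sc(C(=O)c2ccc(OC)cc2)c1C` gives 25.6%, so the steps of a number 37.9 percentage points lower from compound 1 to compound 2 (beyond the scatter) and a number 37.4 percentage points lower from compound 1 to compound 3 (beyond the scatter) are both large, while a number 0.5 percentage points higher from compound 2 to compound 3 (within the scatter) lies within the scatter. Compound 4 `COC(=O)c1c(Nc2ccccc2)sc(C(=O)c2ccc(C)cc2)c1C` differs from compound 1 by methyl in place of methoxy on an aromatic carbon. For the measured compounds named here, no measured step exchanges methoxy for methyl; the measured steps replace hydrogen on an aromatic carbon or swap fluoro for methoxy there. The change in compound 4 is therefore not directly informed, and a modest step, if any, is expected, a number 11 percentage points lower from compound 1 to compound 4 (beyond the scatter). Compound 4 is estimated to give 52% in this assay, between 28% and 76%.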

Compound 4, a percentage reported as activity, at one concentration (the size of the read-out at that concentration, not a potency): 10.3%
The estimate for compound 4 lay 41.7 percentage points above the measured number; measured number below the stated range.
By their numbers in this assay, from the lowest: compound 4; then compounds 2 and 3 (each within the scatter of the next); then compound 1.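

The earlier compounds shown here varied only the aniline ring, and this result shows that the 4-methoxyphenyl on the ketone also matters. In this assay, the change to 4-methylphenyl gives a number 52.7 percentage points lower from compound 1 to compound 4 (beyond the scatter), so on this core a methyl group does not stand in for the methoxy group para to a large group. Nothing measured here accounts for the drop.

On these data alone, it remains open whether the oxygen itself is what counts, which a hydroxyl, an ethoxy group or a dimethylamino group at this place would test. As far as these compounds go, whether hydrogen or fluoro here would fare like methyl also remains open.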